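The source may report more compounds than this note shows. Statements on the series, on what has been measured and on what is new or still open speak of the compounds shown alone.

Within the data shown here, compound 3 `Cc1ccc(-c2nn(-c3ccccc3)c(/N=C/N(C)C)c2C=O)cc1` gives 9700 nM in a functional assay on NPC-TW01 cells (Homo sapiens) for inhibition, read by MTT assay, with a stated time of 72 h (a lower number here means a stronger inhibitor of growth, a higher number a weaker inhibitor of growth), the highest of the three numbers so far, though its neighbours sit within the scatter: compound 1 `Cc1cccc(-n2nc(-c3ccccc3)c(C=O)c2/N=C/N(C)C)c1` gives 8900 nM, and compound 2 `CN(C)/C=N/c1c(C=O)c(-c2ccccc2)nn1-c1cccc(Cl)c1` gives 6400 nM. Among the measured compounds shown here, the one measured step, a 1.4-fold lower number from compound 1 to compound 2 (0.14 log units; within the scatter), concerns chloro in place of methyl on an aromatic carbon and lies within the scatter. Compound 4 `COc1ccc(-c2nn(-c3ccccc3)c(/N=C/N(C)C)c2C=O)cc1` differs from compound 3 by methoxy in place of methyl on an aromatic carbon. For the measured compounds named here, no measured step involves a methoxy, so the only guide is that a single swap on an aromatic carbon left the number where it was. Compound 4 is therefore expected to stay within the scatter, a step of a 1.1-fold lower number from compound 3 to compound 4 (0.03 log units; within the scatter). The estimate for compound 4 in this assay is 9000 nM, between 4000 nM and 20000 nM.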

Compound 4, concentration for 50% growth inhibition: 27200 nM
Compound 4: the middle estimate sits 3.0-fold (0.48 log units) below what was measured; the whole stated range lies below it.
By their numbers in this assay, from the lowest: compounds 2, 1 and 3 (each within the scatter of the next); then compound 4.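

In this assay, the change from 4-methylphenyl to 4-methoxyphenyl gives a 2.8-fold higher number from compound 3 to compound 4 (0.45 log units; beyond the scatter). Among these compounds, this is the first step here beyond the scatter, so a single swap at this place, para to a large group, can move the number. The earlier chloro-for-methyl step, within the scatter, lay elsewhere in the molecule, so it says nothing about this place. Whether a hydroxy group or an amine here would track methyl or methoxy stays open, and nothing given here accounts for the step.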